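From 1H-pyrrol-1-yl to furan-3-yl on a shared core

The source may report more compounds than this note shows. Statements on the series, on what has been measured and on what is new or still open speak of the compounds shown alone.

In a functional assay on MCF7 cells (Homo sapiens) for antiproliferative activity, read by sulforhodamine B assay (on this read-out higher numbers stand for weaker inhibition and lower numbers for stronger inhibition), compound 1 `CN1CCN(c2ccc(N/C=C3\C(=O)NC(=O)c4ccc(-n5cccc5)cc43)cc2)CC1` gives 2300 nM and compound 2 `O=C1NC(=O)c2ccc(-n3cccc3)cc2/C1=C/Nc1ccc(CN2CCCCC2)cc1` gives 2100 nM so the two stand level. The step of a 1.1-fold lower number from compound 1 to compound 2 (0.04 log units; within the scatter) is the only measured one and it lies at a different place, so it bears only loosely on compound 3 `CN1CCN(c2ccc(N/C=C3\C(=O)NC(=O)c4ccc(-c5ccoc5)cc43)cc2)CC1` where furan-3-yl replaces 1H-pyrrol-1-yl on an aromatic carbon (furan-3-yl in place of 1H-pyrrol-1-yl on an aromatic carbon). No measurement covers this swap, so in this assay no change beyond the scatter is expected, and the expected 1.3-fold lower number from compound 1 to compound 3 (0.11 log units; within the scatter) stays small. Compound 3 is estimated at 1800 nM (expected range 600 nM to 5000 nM).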

Compound 3, half-maximal inhibitory concentration: 1100 nM
Compound 3: the middle estimate sits 1.6-fold (0.21 log units) above what was measured; measured number inside the range.
By their numbers in this assay, from the lowest: compounds 3, 2 and 1 (each within the scatter of the next, the first and the last beyond it).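

In this assay, furan-3-yl in place of 1H-pyrrol-1-yl gives a 2.1-fold lower number from compound 1 to compound 3 (0.32 log units; beyond the scatter), a modest change but one beyond the scatter, unlike the earlier step at a different place, a 1.1-fold lower number from compound 1 to compound 2 (0.04 log units; within the scatter). So this position responds even when one five-membered aromatic ring with 1 hetero atom replaces another of the same heavy-atom count. Nothing available explains the shift.

Open, on these data alone, is whether a pyridine ring or a simple amine here would lower the number further, and whether furan-3-yl has the same effect alongside the (piperidin-1-yl)methyl group of compound 2.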